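This account rests on a few compounds, and the source may have more. Where it says the series, first, only, none or still open, it means among the compounds named here.

Measured compounds:
Compound 1 `CC1CCN(C(=O)c2cccc(N/C(=N/O)c3ccc4occc4c3)c2)CC1`. In an assay on tissue (HeLa cells) for inhibition of Indoleamine 2,3-dioxygenase 1 (Homo sapiens), read by spectrophotometry (a higher number here means a weaker inhibitor, a lower number a stronger inhibitor), compound 1 gives > 30000 nM, which is a limit of the assay and not a number.
Compound 2 `O/N=C(/Nc1cccc(Oc2ccccc2)c1)c1ccc2occc2c1`. In this assay compound 2 gives > 30000 nM, again a limit of the assay.
Compound 3 `O/N=C(/Nc1cccc(Cc2ccccc2)c1)c1ccc2occc2c1`. In this assay compound 3 gives > 30000 nM, also a limit of the assay.

Compound 3 therefore stands at a limit only, and the two further values shown are limits as well (the limit of > 30000 nM in this assay, at which 3 of the 3 values shown sit). None of the steps among the measured compounds can be read: from compound 1 to compound 2 a step that the two limits leave unreadable from compound 1 to compound 2, from compound 1 to compound 3 a step that the two limits leave unreadable from compound 1 to compound 3, and from compound 2 to compound 3 a step that the two limits leave unreadable from compound 2 to compound 3.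

Compound 4 `O/N=C(/Nc1cccc(COc2ccccc2)c1)c1ccc2occc2c1` is the next member. It differs from compound 3 by phenoxy in place of phenyl on a saturated chain carbon bound to an aromatic carbon. Among the compounds with values here, the step that bears most directly on it is the one from compound 2 to compound 3 a step that the two limits leave unreadable from compound 2 to compound 3, since compound 4 joins the phenoxy of compound 2 and the chain carbon of compound 3 in one group; that step is unreadable, so no size can be carried over. Within the data shown here, every value in this assay so far sits at the limit (the limit of > 30000 nM in this assay, at which 3 of the 3 values shown sit), and compound 4 is expected to do the same, the expected step from compound 3 to compound 4 being a step that the limit leaves unreadable from compound 3 to compound 4. Compound 4 is estimated at 40000 nM, in the range 15000 nM to 100000 nM, most probably reported again as a limit.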

Compound 4, half-maximal inhibitory concentration: > 30000 nM
Compound 4 was reported as a limit; the forecaster's own chance of this, stated with the estimate: 80%; the middle value does not contradict the limit.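

Compound 4 adds no readable step: its steps from compound 1, compound 2 and compound 3 all join two limits of the assay, so none can be read, and the series remains at one ceiling: the limit of > 30000 nM in this assay, at which 4 of the 4 values shown sit.

The compounds shown leave open how these four rank against each other and which change to the shared core would give a value that is a number.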